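Lengthening the chain of compound 2

This account rests on a few compounds, and the source may have more. Where it says the series, first, only, none or still open, it means among the compounds named here.

In a functional assay on A549 cells (Homo sapiens) for inhibition, read by MTT assay, with a stated time of 72 h (on this read-out higher numbers stand for weaker inhibition and lower numbers for stronger inhibition), compound 1 `Nc1nc2cc(-c3nn(CCCC(=O)NO)c4ncnc(N)c34)ccc2o1` gives > 100000 nM as a limit, not a number. In this assay compound 2 `Nc1ncnc2c1c(-c1cnc3[nH]ccc3c1)nn2CCCCC(=O)NO` gives > 150000 nM as a limit too, so it has no exact value. Compound 3 `Nc1ncnc2c1c(-c1cnc3[nH]ccc3c1)nn2CCCCCCCCCC(=O)NO` carries a longer chain, with 5-(hydroxycarbamoyl)pentyl in place of hydroxycarbamoyl on a saturated chain carbon, four bonds along the chain from an aromatic nitrogen. Among the compounds with values here, no measured pair shows what chain length does, so this is a loose expectation. A large move toward stronger inhibition in this assay is expected, estimated as an at least 7.5-fold lower number from compound 2 to compound 3 (0.87 log units; beyond the scatter). Compound 3 is estimated at 20000 nM, with an expected range from 3000 nM to 150000 nM.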

Compound 3, half-maximal inhibitory concentration: 6550 nM
Compound 3: the middle estimate sits 3.1-fold (0.48 log units) above what was measured; measured number inside the range.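

Exchanging hydroxycarbamoyl for 5-(hydroxycarbamoyl)pentyl on a saturated chain carbon, four bonds along the chain from an aromatic nitrogen, gives an at least 22-fold lower number from compound 2 to compound 3 (1.35 log units; beyond the scatter) in this assay. Within the data shown here, compound 3 is the first compound here with an exact value, so chain length at this position can matter a great deal. Compound 2 has only a limit, not a number, so the full size of the step stays unknown: the limit of > 150000 nM in this assay, at which 1 of the 3 values shown sits.

On these data alone, whether a shorter or still longer chain would do as well remains open. So does the effect of a carboxylic acid in place of hydroxycarbamoyl.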